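Swapping Nitro for Trifluoromethyl in a Cytotoxicity Series

The source may report more compounds than this note shows. Statements on the series, on what has been measured and on what is new or still open speak of the compounds shown alone.

Three analogues built on a shared core have been examined in an ADME assay on HeLa cells (Homo sapiens) for cytotoxicity, read by MTT assay; on this read-out lower numbers stand for stronger inhibition and higher numbers for weaker inhibition. Compound 1 `N#Cc1c(-c2cccc(Cl)c2)c(C#N)c(=O)n(/N=C/c2cn(-c3ccccc3)nc2-c2ccccc2)c1N` carries a 3-chlorophenyl group, and in this assay compound 1 reaches only the limit > 200 ug/mL. Compound 2 `N#Cc1c(-c2cccc(F)c2)c(C#N)c(=O)n(/N=C/c2cn(-c3ccccc3)nc2-c2ccccc2)c1N` carries a 3-fluorophenyl group instead, and in this assay compound 2 likewise reaches only the limit > 200 ug/mL. Compound 3 `N#Cc1c(-c2ccccc2[N+](=O)[O-])c(C#N)c(=O)n(/N=C/c2cn(-c3ccccc3)nc2-c2ccccc2)c1N` carries a 2-nitrophenyl group, and in this assay compound 3 again stands only at the limit > 200 ug/mL. All three therefore sit together at the limit of > 200 ug/mL in this assay, at which 3 of the 3 values shown sit, so none of the steps between them can be sized: a step that the two limits leave unreadable from compound 1 to compound 2, a step that the two limits leave unreadable from compound 1 to compound 3 and a step that the two limits leave unreadable from compound 2 to compound 3.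

Compound 4 `N#Cc1c(-c2ccccc2C(F)(F)F)c(C#N)c(=O)n(/N=C/c2cn(-c3ccccc3)nc2-c2ccccc2)c1N` differs from compound 3 by trifluoromethyl in place of nitro on an aromatic carbon. Each of the measured steps bears on this change only in that none of them produced a readable difference, so for this assay no step beyond the scatter is foreseen and compound 4 is expected to remain at or past the same limit. Compound 4 is accordingly estimated to give about 300 ug/mL, with an expected range from 150 ug/mL to 600 ug/mL. This estimate amounts to an expected step that the limit leaves unreadable from compound 3 to compound 4.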

Compound 4, half-maximal inhibitory concentration: > 200 ug/mL
Compound 4 ended at the assay's limit (the forecaster's own chance of this, stated with the estimate: 85%); the middle value lies beyond the limit too.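

Among these compounds, compound 4 also stands only at a limit in this assay, so no step linking it to compound 1, compound 2 or compound 3 can be read: the limit of > 200 ug/mL in this assay, at which 4 of the 4 values shown sit. The compounds shown leave open how far apart any of them truly lie in this assay.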